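Taking the fluoro group off compound 1

The compounds below may be only part of what the source reports. "The series", "measured", "known", "first", "only" and "open" are said of these compounds alone.

Within the data shown here, in a functional assay on T98G cells (Homo sapiens) for cytotoxicity, read by MTT assay, with a stated time of 48 h (on this read-out lower numbers stand for stronger inhibition and higher numbers for weaker inhibition), compound 1 `CC(=NNC(=S)Nc1ccccc1F)c1ccccn1` gives 3.1 nM, level with compound 3 `C/C(=N/NC(=S)Nc1ccccc1F)c1ccccn1` at 3.1 nM, and these two share the lowest number so far. Compound 4 `CC(=NNC(=S)Nc1ccccc1)c1ccccn1` has yet to be measured. It differs from compound 1 by hydrogen in place of fluoro on an aromatic carbon, with hydrogen in place of fluoro on an aromatic carbon. Among the measured compounds shown here, the one measured step, no change at the digits printed from compound 1 to compound 3 (within the scatter), concerns only how a double bond is drawn, so it says little about this change. For the measured compounds named here, compound 2 `C/C(=N\NC(=S)Nc1ccc(I)cc1)c1ccccn1`, an iodo analogue at 64 nM, shows only that numbers in this set can lie well higher. The expected step is a modest rise, a 2.6-fold higher number from compound 1 to compound 4 (0.41 log units; beyond the scatter). Compound 4 is estimated at 8 nM, within an expected range of 2 nM to 40 nM.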

Compound 4, half-maximal inhibitory concentration: 6.8 nM
The estimate for compound 4 lay 1.2-fold (0.07 log units) above the measured number; the range from low to high includes it.
By their numbers in this assay, from the lowest: compounds 1 and 3 (each within the scatter of the next); then compound 4; then compound 2.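

In this assay, swapping the fluoro group for hydrogen on this aromatic carbon, ortho to a large group, has a real but modest cost: a 2.2-fold higher number from compound 1 to compound 4 (0.34 log units; beyond the scatter). The fluoro group therefore helps a little, yet it is not needed for a low number, since compound 4 still gives 6.8 nM. No measurement shown here explains this shift.

Only fluoro and hydrogen can be compared at this place. As far as these compounds go, whether chloro, methyl or methoxy there would match fluoro, or go beyond it, remains open.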